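The source may report more compounds than this note shows. Statements on the series, on what has been measured and on what is new or still open speak of the compounds shown alone.

Among the measured compounds shown here, compound 2 `Cc1ccc2c(C3CCN(CCN4CCNC4=O)CC3)cn(-c3ccc(F)cc3)c2c1` gives 24 nM in an assay on cell membranes for displacement of a labelled ligand from Adrenergic receptor alpha-1 (Rattus norvegicus) (on this read-out lower numbers stand for stronger inhibition and higher numbers for weaker inhibition), the lowest of the two numbers measured so far; compound 1 `Cc1ccc2c(C3CCN(CCN4CCN(C(C)C)C4=O)CC3)cn(-c3ccc(F)cc3)c2c1` gives 85 nM, and the only step available is a 3.5-fold lower number from compound 1 to compound 2 (0.55 log units; beyond the scatter). Compound 3 `O=C1NCCN1CCN1CCC(c2cn(-c3ccc(F)cc3)c3cc(F)ccc23)CC1` differs from compound 2 by fluoro in place of methyl on an aromatic carbon. For the measured compounds named here, the one measured step concerns the amide-type ring nitrogen and does not bear on an exchange at an aromatic carbon; nothing in these two compounds speaks to such a change. The step to compound 3 is therefore expected to stay within the scatter, a 1.0-fold higher number from compound 2 to compound 3 (0.02 log units; within the scatter). Compound 3 is estimated at 25 nM, with a range from 8 nM to 75 nM.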

Compound 3, half-maximal inhibitory concentration: 2.2 nM
Compound 3: middle estimate off by 11-fold (1.06 log units), on the high side, and the stated range ends above it.
By their numbers in this assay, from the lowest: compound 3; then compound 2; then compound 1.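

In this assay the exchange of methyl for fluoro on this aromatic carbon gives an 11-fold lower number from compound 2 to compound 3 (1.04 log units; beyond the scatter) and so this position of the shared core responds strongly to a change of a single heavy atom. The counted donors, acceptors and net charge stay the same across this exchange. Nothing shown here accounts for the size of the step.

It remains open whether the gain follows from fluoro entering or methyl leaving, as chloro, methoxy and plain hydrogen at this carbon are not among the compounds shown. Also open, on these data alone, is whether the step holds with isopropyl on the amide-type ring nitrogen.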